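Sulfonamide aryl variation on a shared benzylamide core

This account rests on a few compounds, and the source may have more. Where it says the series, first, only, none or still open, it means among the compounds named here.

Measured compounds:
compound 1 `O=C(NCc1ccc(CNS(=O)(=O)c2ccc(CN3CCCC3)cc2)cc1)c1ccc(F)cc1`: 1 nM
compound 2 `O=C(NCc1ccc(CNS(=O)(=O)c2ccc(Cl)cc2)cc1)c1ccc(F)cc1`: 100 nM
compound 3 `Cc1ccccc1S(=O)(=O)NCc1ccc(CNC(=O)c2ccc(F)cc2)cc1`: 100 nM

In an assay on MDA-MB-231 cells for binding affinity to C-X-C chemokine receptor type 4 (Homo sapiens), read by fluorescence and microscopy, with stated times of 10 min and 30 min (on this read-out higher numbers stand for an effect only at larger amounts of compound and lower numbers for an effect already at smaller amounts), compound 3 gives 100 nM, level with compound 2 and together with it the highest number of the three; compound 1 stands far lower, as shown by a 100-fold higher number from compound 1 to compound 2 (2.00 log units; beyond the scatter). The next member, compound 4 `O=C(NCc1ccc(CNS(=O)(=O)c2ccc(F)cc2)cc1)c1ccc(F)cc1`, differs from compound 3 by 4-fluorophenyl in place of 2-methylphenyl on a sulfonyl sulfur. Going by the values given here, the only step that bears on this change is the earlier swap of the aryl group on the sulfonyl sulfur, no change at the digits printed from compound 2 to compound 3 (within the scatter), which stayed within the scatter. The large step of a 100-fold higher number from compound 1 to compound 2 (2.00 log units; beyond the scatter) concerns a different place on the core and offers no guidance here. For compound 4 the expected step is therefore no change at the digits printed from compound 3 to compound 4 (within the scatter), nothing beyond the scatter. Compound 4 is estimated at 100 nM, with a range from 40 nM to 300 nM.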

Compound 4, effective concentration (reported as EC, without a stated level of effect): 1 nM
The estimate for compound 4 lay 100-fold (2.00 log units) above the measured number; the whole stated range lies above it.
By their numbers in this assay, from the lowest: compounds 1 and 4 (each within the scatter of the next); then compounds 2 and 3 (each within the scatter of the next).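

Unlike the earlier swap on the sulfonyl sulfur, which stayed within the scatter, 4-fluorophenyl in place of 2-methylphenyl gives a 100-fold lower number from compound 3 to compound 4 (2.00 log units; beyond the scatter) and shows that this position is sensitive to the aryl group. Fluoro in place of chloro on an aromatic carbon gives a 100-fold lower number from compound 2 to compound 4 (2.00 log units; beyond the scatter), so even this single halogen swap carries a large step. The (pyrrolidin-1-yl)methyl group is not required for the low number, with no change at the digits printed from compound 1 to compound 4 (within the scatter) as fluoro takes its place.

Open, from the compounds shown here alone, is how a bromo, a methoxy or a primary amine on that aromatic carbon would read, and whether 2-fluorophenyl on the sulfonyl sulfur would follow 4-fluorophenyl or 2-methylphenyl. No measured evidence accounts for these steps.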